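Swapping the Amine of Compound 1

A few compounds are considered here, and "the series" means these few. Any claim that something is new, unique, unknown or untested is made for them only; others in the source may bear on it.

Compound 1 `CCN(CC)CC1(c2ccc(Cl)c(Cl)c2)CCCCC1` was tested in an assay on isolated protein for inhibition of sodium-dependent dopamine transporter (Homo sapiens); on this read-out lower numbers stand for stronger inhibition and higher numbers for weaker inhibition. For compound 1 the result is only a limit of the assay, < 1 nM, so its true position on the scale is not fixed (the limit of < 1 nM in this assay, at which 1 of the 2 values shown sits). Compound 2 `CN(C)CC1(c2ccc(Cl)c(Cl)c2)CCCC1` gives 9 nM in this assay; it differs from compound 1 in more than one place, so only the two values can be set side by side. Compound 3 `CN1CCN(CC2(c3ccc(Cl)c(Cl)c3)CCCCC2)CC1` carries 4-methylpiperazin-1-yl in place of diethylamino on a saturated chain carbon bound to a saturated ring carbon. For the measured compounds named here, no measured step of this kind exists here; the change is expected to weaken inhibition beyond the scatter, an at least 12-fold higher number from compound 1 to compound 3 (1.07 log units; beyond the scatter). Compound 3 is estimated at 12 nM, between 2 nM and 70 nM.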

Compound 3, half-maximal inhibitory concentration: < 1 nM
Compound 3: a limit, no number; the forecaster's own chance of this, stated with the estimate: 10%; at least 12-fold (1.07 log units) between middle value and limit.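

In this assay compound 3 gives < 1 nM, which is a limit and not a number. Compound 1 also stands at a limit, so no step can be read from compound 1 to compound 3: the limit of < 1 nM in this assay, at which 2 of the 3 values shown sit.

As far as these compounds go, how strongly either compound inhibits, and so what 4-methylpiperazin-1-yl in place of diethylamino does to inhibition, stays open.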